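The source may hold more compounds than are shown below. What is called first, only, known or untested is meant among the compounds shown, and "the series" means these compounds.

Compound 1: `CC(C)c1ccccc1NC(=O)N[C@@H](C)c1ccccc1` — 96%
Compound 2: `C[C@H](NC(=O)Nc1ccccc1C(C)(C)C)c1ccccc1` — 99%
Compound 3: `C[C@H](NC(=O)Nc1ccccc1C(F)(F)F)c1ccccc1` — 98%

In an ADME assay on the whole organism with Oryza sativa as the target, tested at 1 uM (a higher number here means a weaker effect of the compound at the concentration tested, a lower number a stronger effect), compound 3 gives 98%, the second highest of the three numbers. Its nearest neighbour is compound 2, and the step of a number 1 percentage points lower from compound 2 to compound 3 (within the scatter) is within the scatter. Compound 1 is the furthest away, yet the step of a number 2 percentage points higher from compound 1 to compound 3 (within the scatter) is also within the scatter, so all three compounds sit together at a high reading.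

Compound 4 is `C[C@H](NC(=O)Nc1ccccc1F)c1ccccc1`. It differs from compound 3 by fluoro in place of trifluoromethyl on an aromatic carbon. Among the measured compounds shown here, no measured step swaps exactly these two groups, but two steps change the group on the same aromatic carbon: a number 2 percentage points higher from compound 1 to compound 3 (within the scatter) and a number 1 percentage points lower from compound 2 to compound 3 (within the scatter), both within the scatter. Varying this group has so far moved nothing beyond the scatter, so the step from compound 3 to compound 4 in this assay is expected to be a number 2 percentage points lower from compound 3 to compound 4 (within the scatter), with no change beyond the scatter. Compound 4 is therefore estimated at 96%, within a range from 88% to 100%.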

Compound 4, a percentage reported as activity, at one concentration (the size of the read-out at that concentration, not a potency): 92%
Compound 4: the middle estimate sits 4 percentage points above what was measured; the range from low to high includes it.
By their numbers in this assay, from the lowest: compounds 4, 1, 3 and 2 (each within the scatter of the next).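

Swapping trifluoromethyl, with 4 heavy atoms, for fluoro, with 1 heavy atom, on an aromatic carbon ortho to a large group does not move the reading beyond the scatter in this assay. The steps of a number 6 percentage points lower from compound 3 to compound 4 (within the scatter) and a number 7 percentage points lower from compound 2 to compound 4 (within the scatter) and a number 4 percentage points lower from compound 1 to compound 4 (within the scatter) all show the same thing, so fluoro now joins isopropyl, tert-butyl and trifluoromethyl as groups at this position that give readings within the scatter of one another. No measurement here offers an explanation for this result.

Still open, on these data alone, is whether an amine or a carboxylic acid on this aromatic carbon would shift the reading beyond the scatter. As far as these compounds go, all four compounds also have the same shared core, so the effect of a change elsewhere in it remains unknown.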